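The source may hold more compounds than are shown below. What is called first, only, known or untested is meant among the compounds shown, and "the series" means these compounds.

Measured so far in a functional assay on HeLa cells (Homo sapiens) for inhibition; a higher number here means a weaker inhibitor, a lower number a stronger inhibitor:
Compound 1, `CC(O)n1cnc2c(Cl)nc(I)nc21`, gives > 500000 nM, a limit of the assay and not a number.
Compound 2, `CC(O)n1cnc2c(N)nc(I)nc21`, gives > 500000 nM, also a limit of the assay rather than a number.

Going by the values given here, compound 2 thus stands only at a limit in this assay , and the one other value shown is a limit as well. Among the compounds with values here, the single measured step, a step that the two limits leave unreadable from compound 1 to compound 2, has no readable size because both of its ends rest on (the limit of > 500000 nM in this assay, at which 2 of the 2 values shown sit).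

Compound 3, `Nc1nc(I)nc2c1ncn2OCCO`, differs from compound 2 in one place: 2-hydroxyethoxy in place of 1-hydroxyethyl on an aromatic nitrogen. No measured step bears on this change, since the only step shown cannot be read. The expectation for compound 3 in this assay therefore rests on the fact that compound 2 is found at the limit and nothing else. Compound 3 is expected to give 500000 nM, with a range from 100000 nM to 2000000 nM, and it will most likely be reported as a limit again. The expected step of a number no higher from compound 2 to compound 3 (the limit leaves the size open) is thus none that can be told from the scatter.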

Compound 3, half-maximal inhibitory concentration: > 500000 nM
Compound 3 gave a limit, no number; the forecaster's own chance of this, stated with the estimate: 85%; the middle value sits exactly at the limit.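

In this assay compound 3 gives > 500000 nM, a limit of the assay and not a number. The step between compound 2 and compound 3 cannot be read, because both of its ends rest on the same limit: the limit of > 500000 nM in this assay, at which 3 of the 3 values shown sit. The compounds shown leave open how strong any of them is, and whether 2-hydroxyethoxy in place of 1-hydroxyethyl changes inhibition at all.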